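This account rests on a few compounds, and the source may have more. Where it says the series, first, only, none or still open, it means among the compounds named here.

The study looked at two quinolinone-bearing tertiary amines in a toxicity assay on MDCK cells (Canis lupus familiaris) for cytotoxicity, read by crystal violet staining, with a stated time of 48 h; on this read-out lower numbers stand for higher toxicity in this test and higher numbers for lower toxicity in this test. Compound 1, `Cc1ccc2[nH]c(=O)c(CN(Cc3ccc(F)cc3)Cc3cccc4ccccc34)cc2c1`, sits at the limit of this assay: in this assay compound 1 gives > 5000 nM, which is a limit rather than a number. Going by the values given here, compound 2, `COCOc1ccc(CN(Cc2ccc(C(C)(C)C)cc2)Cc2cc3cc(C)ccc3[nH]c2=O)cc1`, is the only compound with an actual number here; in this assay compound 2 gives 6400 nM. Compound 2 therefore stands as the one measured point, with the other value being a limit, as the limit of > 5000 nM in this assay, at which 1 of the 2 values shown sits, shows.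

The third compound, compound 3, `Cc1ccc2[nH]c(=O)c(CN(Cc3ccc(C(C)(C)C)cc3)C(C)c3ccc(N(C)C)c(Cl)c3)cc2c1`, has not yet been measured in this assay. It differs from compound 2 in one place: 1-(3-chloro-4-(dimethylamino)phenyl)ethyl in place of 4-(methoxymethoxy)benzyl on an amine nitrogen.

Among the compounds with values here, no step between two measured compounds is available to set the size of this change. Within the data shown here, with compound 2 at 6400 nM, the one actual number points to low toxicity. The step of a 1.4-fold lower number from compound 2 to compound 3 (0.15 log units; within the scatter) is expected to stay within the usual scatter, with at most a modest move toward higher toxicity. Compound 3 is estimated to give 4500 nM in this assay, with a range from 1500 nM to 13000 nM.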

Compound 3, half-maximal cytotoxic concentration: 9800 nM
For compound 3 the middle estimate is 2.2-fold (0.34 log units) below the measured one; low and high end bracket the measured number.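

Going by these compounds alone, the swap of 4-(methoxymethoxy)benzyl for 1-(3-chloro-4-(dimethylamino)phenyl)ethyl on an amine nitrogen gives a 1.5-fold higher number from compound 2 to compound 3 (0.19 log units; within the scatter), the first step in this assay between two measured compounds. For this one pair, the position takes an entering group with chlorine and nitrogen in its atom count, where the leaving group has two oxygens, and the read-out does not move beyond the scatter. Compound 1 remains a limit rather than a number, and it offers no second step to set beside this one: the limit of > 5000 nM in this assay, at which 1 of the 3 values shown sits.

This single step replaces the whole group at once, so the compounds shown cannot separate what the chlorine, the dimethylamino group and the ethyl link each contribute, and one pair cannot show whether the same holds for other groups on this amine nitrogen. A group carrying a carboxylic acid, a primary amine or a longer chain in that place might stay within the scatter of compound 2 or might move beyond it, and the compounds shown do not tell which.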